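Swapping Bromo for Methyl on a Benzyl Ether Series

The source may report more compounds than this note shows. Statements on the series, on what has been measured and on what is new or still open speak of the compounds shown alone.

Measured so far:
- Compound 1 `O=C1CCCc2cc(OCc3cccc(Cl)c3)ccc21`: 15 nM
- Compound 2 `O=C1CCCc2cc(OCc3ccc(Br)cc3)ccc21`: 9 nM
- Compound 3 `O=C1CCCc2cc(OCc3cccc(I)c3)ccc21`: 4.5 nM

All three share one core and differ only in the halogen on the outer ring. In an assay on isolated protein for inhibition of Amine oxidase [flavin-containing] B (Homo sapiens), read by fluorescence and spectrophotometry, with a stated time of 30 min (a lower number here means a stronger inhibitor, a higher number a weaker inhibitor), compound 2 gives a number that lies within the scatter of both compound 1 and compound 3, so no ordering among the three can be claimed from these values alone. Among the compounds with values here, the one step that is resolved runs a 3.3-fold lower number from compound 1 to compound 3 (0.52 log units; beyond the scatter); it shows that exchanging one halogen for another moves the number only modestly.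

Compound 4 `Cc1ccc(COc2ccc3c(c2)CCCC3=O)cc1` has not yet been measured. It differs from compound 2 by methyl in place of bromo on an aromatic carbon. Within the data shown here, no measured pair exchanges a halogen for a carbon group, so the only guide is the halogen-swap step above, which was modest in size. A small shift is therefore expected, in either direction, most likely not beyond the scatter. The expected step is a 1.3-fold higher number from compound 2 to compound 4 (0.12 log units; within the scatter). For compound 4 the estimate in this assay is 12 nM, with a range from 4 nM to 35 nM.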

Compound 4, half-maximal inhibitory concentration: 11 nM
Beside the measured number, compound 4's estimate is 1.1-fold (0.04 log units) above it; the measured number falls inside the stated range.
By their numbers in this assay, from the lowest: compounds 3, 2, 4 and 1 (each within the scatter of the next, the first and the last beyond it).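

The step of a 1.2-fold higher number from compound 2 to compound 4 (0.09 log units; within the scatter) shows that, in this assay, a carbon group can take the place of a halogen on this aromatic carbon, para to a large group, without a difference that can be told from the scatter. Within the data shown here, the earlier compounds exchanged only one halogen for another, so this is the first sign that a halogen is not needed here for a number in this range. Nothing measured here accounts for how closely methyl and bromo agree.

A larger or quite different group on this carbon, such as an amine, a carboxylic acid or a longer chain, remains untested in the compounds shown. Also open, going by these compounds, is how methyl would read at the place that carries chloro in compound 1 and iodo in compound 3.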